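Isopropyl to ethyl: a small step expected

The source may report more compounds than this note shows. Statements on the series, on what has been measured and on what is new or still open speak of the compounds shown alone.

In an ADME assay on L6 cells (Rattus norvegicus) for cytotoxicity, read by resazurin assay, with a stated time of 70 h (a higher number here means that more compound is needed for the effect, a lower number that less compound is needed), compound 3 (`CC(C)[C@H]1CC[C@H](n2c(=O)[nH]c3ncc(N)cc3c2=O)CC1`) gives 46000 nM. Compound 2 (`CC(C)(C)[C@H]1CC[C@H](n2c(=O)[nH]c3ncc(N)cc3c2=O)CC1`) gives 63000 nM, within the scatter of compound 3. Compound 1 (`CC[C@H]1CC[C@H](n2c(=O)[nH]c3ncc(NC(C)=O)cc3c2=O)CC1`) gives 215000 nM, beyond the scatter of compound 3.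

Compound 4 (`CC[C@H]1CC[C@H](n2c(=O)[nH]c3ncc(N)cc3c2=O)CC1`) differs from compound 3 by hydrogen in place of methyl on a saturated chain carbon bound to a saturated chain carbon and a saturated ring carbon, which is hydrogen in place of methyl on a saturated chain carbon bound to a saturated chain carbon and a saturated ring carbon. Within the data shown here, the one measured step of this kind is a 1.4-fold lower number from compound 2 to compound 3 (0.14 log units; within the scatter). It also trades methyl for hydrogen, so no change beyond the scatter is expected in this assay. The expected step is a 1.1-fold lower number from compound 3 to compound 4 (0.04 log units; within the scatter). The estimate for compound 4 is 42000 nM, with an expected range of 21000 nM to 90000 nM.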

Compound 4, half-maximal effective concentration in the L6 assay: 51000 nM
Beside the measured number, compound 4's estimate is 1.2-fold (0.08 log units) below it, within the range that was stated.
By their numbers in the L6 assay, from the lowest: compounds 3, 4 and 2 (each within the scatter of the next); then compound 1.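

In the L6 assay, the group on the saturated ring carbon can shrink from tert-butyl or isopropyl to ethyl with no change beyond the scatter: a 1.2-fold lower number from compound 2 to compound 4 (0.09 log units; within the scatter), and a 1.1-fold higher number from compound 3 to compound 4 (0.04 log units; within the scatter). In the L6 assay, the step beyond the scatter lies instead at the nitrogen on an aromatic ring, where hydrogen replaces acetyl: a 4.2-fold lower number from compound 1 to compound 4 (0.62 log units; beyond the scatter). In a physicochemical assay for solubility, read by nephelometry, measured as kinetic solubility (on this read-out lower numbers stand for lower solubility and higher numbers for higher solubility), compound 3 gives 25000 nM and compound 4 gives 55000 nM. Isopropyl to ethyl does separate the compounds in the physicochemical assay, a change the L6 assay does not show: the measured solubility of compound 3, 25000 nM, and of compound 4, 55000 nM, a 2.2-fold higher number (0.34 log units; beyond the scatter)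

Open, from the compounds shown here alone, is whether a longer chain, an amine or a carboxylic acid on that ring carbon would keep the L6 assay as flat. Also open, going by these compounds, is whether the rise in solubility seen with ethyl would carry over to such groups.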